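The compounds below may be only part of what the source reports. "The series", "measured", "known", "first", "only" and "open" are said of these compounds alone.

Of the compounds shown here, three of one shared core have been tested in a functional assay on cells (Hepatocyte, Homo sapiens) for inhibition, with a stated time of 10 min; a higher number here means a weaker inhibitor, a lower number a stronger inhibitor. Compound 1 `O=C(O)CCNC(=O)c1ccc(CN(c2ccc(Cl)cc2)c2nc(-c3ccc(OC(F)(F)F)cc3)cs2)cc1` gives 2800 nM in this assay. Compound 3 `O=C(O)CCNC(=O)c1ccc(CN(c2ccc3c(c2)CCCC3)c2nc(-c3ccc(Cl)c(Cl)c3)cs2)cc1` gives 4000 nM in this assay. For compound 2 `O=C(O)CCNC(=O)c1ccc(CN(c2ccc3c(c2)CCC3)c2nc(-c3ccc(C(F)(F)F)cc3)cs2)cc1` this assay reports only a limit, < 20000 nM, and not a number. That limit is the one at which one of the three values sits (the limit of < 20000 nM in this assay, at which 1 of the 3 values shown sits), so compound 2 is placed only loosely among the numbers shown; what is known is that it does inhibit within the measured range, not how strongly compared with compound 1 or compound 3.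

The step followed here leads from compound 2 to compound 4 `O=C(O)CCNC(=O)c1ccc(CN(c2ccc(Cl)cc2)c2nc(-c3ccc(C(F)(F)F)cc3)cs2)cc1`, which has not yet been measured in this assay. The change is 4-chlorophenyl in place of 2,3-dihydro-1H-inden-5-yl on a nitrogen on an aromatic ring. Compound 4 thereby carries the same 4-chlorophenyl group on that nitrogen as compound 1, whose value is 2800 nM, and so the expectation for compound 4 is a number of that order. The step that the limit leaves unreadable from compound 2 to compound 4 is therefore expected to bring compound 4 to a measured value rather than a limit, without a large shift beyond the usual scatter. For compound 4 the estimate in this assay is 3000 nM, with a range from 1000 nM to 9000 nM.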

Compound 4, half-maximal inhibitory concentration: 2700 nM
Estimate against measurement, compound 4: 1.1-fold (0.05 log units) above; measured number inside the range.
By their numbers in this assay, from the lowest: compounds 4, 1 and 3 (each within the scatter of the next).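

In this assay, the shared core now yields its first readable single change: trifluoromethyl in place of trifluoromethoxy on an aromatic carbon is a 1.0-fold lower number from compound 1 to compound 4 (0.02 log units; within the scatter). Within the data shown here, with 4-chlorophenyl held on the nitrogen, this assay therefore does not tell these two groups apart at this position, a comparison that the earlier compounds, which all differ in more than one place, could not offer. The change on the nitrogen itself, 4-chlorophenyl in place of 2,3-dihydro-1H-inden-5-yl, cannot be read, since the value of compound 2 is a limit and not a number: the limit of < 20000 nM in this assay, at which 1 of the 4 values shown sits.

As far as these compounds go, the effect of that nitrogen substituent on its own therefore remains open, and a measured number for compound 2 would be needed to settle it. Also open, from the compounds shown here alone, is whether a nitrile or a methoxy group on that aromatic carbon, or a primary amide in place of the carboxylic acid, would keep the number within the scatter of compound 1 and compound 4.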